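Undoing a Side-Chain Swap on a Shared Core

The source may hold more compounds than are shown below. What is called first, only, known or untested is meant among the compounds shown, and "the series" means these compounds.

Compound 2 `CC/N=C(\S)NCCCCCn1nc(-c2ccccc2)ccc1=O` is one of three compounds with the same core and a long saturated chain ending in a small, sulfur-containing group. In a functional assay on the whole organism (stomach) with Rattus norvegicus as the target (on this read-out higher numbers stand for an effect only at larger amounts of compound and lower numbers for an effect already at smaller amounts), compound 2 gives 51.8 mg/kg. Compound 1 `CN(C)/C(=N/CCCCn1nc(-c2ccccc2)ccc1=O)NC#N` carries a nitrogen-rich end group on the same chain; in this assay compound 1 gives 30.3 mg/kg. The two sit close together: a 1.7-fold higher number from compound 1 to compound 2 (0.23 log units; within the scatter). Of the two full numbers, compound 2 has the higher one, with compound 1 as its nearest neighbour. Compound 3 `CC(C)(C)/N=C(\S)NCCCCn1nc(-c2ccccc2)ccc1=O` reaches in this assay only a limit, > 100 mg/kg, which is the limit of > 100 mg/kg in this assay, at which 1 of the 3 values shown sits. From there, an at least 3.3-fold higher number from compound 1 to compound 3 (0.51 log units; beyond the scatter), and an at least 1.9-fold higher number from compound 2 to compound 3 (0.28 log units; that floor lies within the scatter).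

Compound 4 `CN(C)/C(=N/CCCn1nc(-c2ccccc2)ccc1=O)NC#N` takes the end group of compound 1 and sits it on a chain one link shorter: a group of 8 heavy atoms (4 carbon, 4 nitrogen; no ring) in place of a group of 8 heavy atoms (5 carbon, 2 nitrogen, 1 sulfur; no ring), on a saturated chain carbon, three bonds along the chain from an aromatic nitrogen. Among the measured compounds shown here, the step that bears most on it is the one between compound 1 and compound 2, which stayed within the scatter, so the return swap is expected to move little in this assay. For the measured compounds named here, the shorter chain has no measured counterpart here. Compound 4 is expected at 30 mg/kg, within 14 mg/kg to 70 mg/kg, which would mean a 1.7-fold lower number from compound 2 to compound 4 (0.24 log units; within the scatter).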

Compound 4, dose for half-maximal effect: 53 mg/kg
Compound 4: the middle estimate sits 1.8-fold (0.25 log units) below what was measured; the measured number falls inside the stated range.
By their numbers in this assay, from the lowest: compounds 1, 2 and 4 (each within the scatter of the next). At a limit, above all of these: compound 3.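

Swapping the sulfur-containing end group for the nitrogen-rich one with its nitrile, on a saturated chain carbon three bonds along the chain from an aromatic nitrogen, leaves the read-out in place: there is a 1.0-fold higher number from compound 2 to compound 4 (0.01 log units; within the scatter). The earlier compounds shown here showed this kind of closeness only for the two end groups on other chain positions, so compound 4 extends it to a shorter chain, even though the entering group has one hydrogen-bond donor and two acceptors where the leaving group has two donors and one acceptor. Compound 3 remains the only compound in the set that reaches a limit and not a full number: the limit of > 100 mg/kg in this assay, at which 1 of the 4 values shown sits.

The compounds shown do not separate the effect of the end group from that of the chain, since compound 4 differs from compound 2 in both, and neither the sulfur-containing end group on this shorter chain nor the pair of chain lengths under one end group has a listed step. As far as these compounds go, whether a longer chain, or an amine or a carboxylic acid in place of these end groups, would stay this close in this assay remains open.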